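The compounds below may be only part of what the source reports. "The series", "measured", "known", "first", "only" and "open" are said of these compounds alone.

Compound 1 `CNC(=O)C[C@@H]1C[C@@H](c2ccc(Cl)c(Cl)c2)[C@H](NC(=O)c2cc(-c3c(Cl)cnn3C)c(Cl)o2)CN1` is measured in an assay for inhibition of RAC-alpha serine/threonine-protein kinase (Homo sapiens), read by HTRF, with a stated time of 1 h (a higher number here means a weaker inhibitor, a lower number a stronger inhibitor), and gives 2.64 nM, the second highest of the three numbers recorded. Compound 2 `Cn1ncc(Cl)c1-c1cc(C(=O)N[C@@H]2CN[C@H](CCCO)C[C@H]2c2ccc(Cl)c(Cl)c2)oc1Cl` gives 2.56 nM in this assay, a step of a 1.0-fold lower number from compound 1 to compound 2 (0.01 log units; within the scatter), and compound 3 `Cn1ncc(Cl)c1-c1cc(C(=O)N[C@@H]2CN[C@H](CC(=O)NC3CC3)C[C@H]2c2ccc(Cl)c(Cl)c2)oc1Cl` gives 3.95 nM, a step of a 1.5-fold higher number from compound 1 to compound 3 (0.17 log units; within the scatter). Compound 4 `Cn1ncc(Cl)c1-c1cc(C(=O)N[C@@H]2CN[C@H](CC(=O)NCCO)C[C@H]2c2ccc(Cl)c(Cl)c2)oc1Cl` differs from compound 1 by hydroxymethyl in place of hydrogen on a saturated chain carbon bound to an amide-type nitrogen. The step that bears on it most closely is the change on the amide-type nitrogen from compound 1 to compound 3, a 1.5-fold higher number from compound 1 to compound 3 (0.17 log units; within the scatter), which stayed within the scatter; the change at the chain carbon, a 1.5-fold higher number from compound 2 to compound 3 (0.19 log units; within the scatter), also did. No step beyond the scatter is therefore expected, and compound 4 is estimated at 3 nM in this assay, between 1.5 nM and 6 nM, a step of a 1.1-fold higher number from compound 1 to compound 4 (0.06 log units; within the scatter).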

Compound 4, half-maximal inhibitory concentration: 1.41 nM
Beside the measured number, compound 4's estimate is 2.1-fold (0.33 log units) above it; the measured number lies below the stated range.
By their numbers in this assay, from the lowest: compounds 4, 2, 1 and 3 (each within the scatter of the next, the first and the last beyond it).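

In this assay, hydroxymethyl in place of hydrogen on a saturated chain carbon bound to an amide-type nitrogen stays within the scatter (a 1.9-fold lower number from compound 1 to compound 4 (0.27 log units; within the scatter)), as does (2-hydroxyethyl)carbamoyl in place of 2-hydroxyethyl (a 1.8-fold lower number from compound 2 to compound 4 (0.26 log units; within the scatter)). The earlier compounds shown here showed no step beyond the scatter, but 2-hydroxyethyl in place of cyclopropyl on the amide-type nitrogen gives a modest one (a 2.8-fold lower number from compound 3 to compound 4 (0.45 log units; beyond the scatter)). No measured finding explains this step. The compounds shown leave open whether a longer chain, an amine or a carboxylic acid in place of 2-hydroxyethyl on the amide-type nitrogen would give a step beyond the scatter from compound 4.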